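Stripping halogens and the urea nitrogen from the amide

A few compounds are considered here, and "the series" means these few. Any claim that something is new, unique, unknown or untested is made for them only; others in the source may bear on it.

Three measured compounds share one core and differ only in the group on the carbonyl carbon. Compound 3 `COc1cc(-c2nn(-c3cccc(NC(=O)Nc4ccc(Cl)c(C(F)(F)F)c4)c3)cc2-c2ccncc2)ccc1Cl` stands lowest of the two plain numbers in a functional assay on NCI-H460 cells (Homo sapiens) for inhibition, read by sulforhodamine B assay, with a stated time of 48 h (on this read-out higher numbers stand for weaker inhibition of growth and lower numbers for stronger inhibition of growth), where compound 3 gives 4790 nM. Compound 1 `COc1cc(-c2nn(-c3cccc(NC(=O)c4cccc(C(F)(F)F)c4)c3)cc2-c2ccncc2)ccc1Cl` gives 9270 nM. For compound 2 `COc1cc(-c2nn(-c3cccc(NC(=O)c4ccc(Cl)c(C(F)(F)F)c4)c3)cc2-c2ccncc2)ccc1Cl` the result is only a limit, > 32500 nM, which is the limit of > 32500 nM in this assay, at which 1 of the 3 values shown sits. The change an at least 3.5-fold higher number from compound 1 to compound 2 (0.54 log units; beyond the scatter) shows the added chloro weakening growth inhibition, while a 1.9-fold lower number from compound 1 to compound 3 (0.29 log units; within the scatter) and an at least 6.7-fold lower number from compound 2 to compound 3 (0.83 log units; beyond the scatter) show that the urea linkage to the halogenated aryl group holds or recovers potency.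

Compound 4 `COc1cc(-c2nn(-c3cccc(NC(=O)c4ccccc4)c3)cc2-c2ccncc2)ccc1Cl` carries the change (phenyl in place of (4-chloro-3-(trifluoromethyl)phenyl)amino on a carbonyl carbon), so it loses both the urea nitrogen and the halogens at once. The steps of a 1.9-fold lower number from compound 1 to compound 3 (0.29 log units; within the scatter) and an at least 6.7-fold lower number from compound 2 to compound 3 (0.83 log units; beyond the scatter) bear on it, as does an at least 3.5-fold higher number from compound 1 to compound 2 (0.54 log units; beyond the scatter) in reverse; together they suggest the halogenated urea of compound 3 is favourable, so a modestly higher number is expected, a 2.9-fold higher number from compound 3 to compound 4 (0.47 log units; beyond the scatter). Compound 4 is therefore estimated at 14000 nM in this assay, within 5000 nM to 40000 nM.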

Compound 4, concentration for total growth inhibition: > 100000 nM
Compound 4: a limit, no number; the forecaster's own chance of this, stated with the estimate: 25%; middle value at least 7.1-fold (0.85 log units) away from the limit.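

The result for compound 4 in this assay is a limit and not a number: the limit of > 100000 nM in this assay, at which 1 of the 4 values shown sits. Plain phenyl on the carbonyl carbon costs far more than any step among the earlier compounds could show, with an at least 20-fold higher number from compound 3 to compound 4 (1.31 log units; beyond the scatter), and the loss is also large when only the trifluoromethyl goes, with an at least 10-fold higher number from compound 1 to compound 4 (1.03 log units; beyond the scatter). Within the amides, then, the trifluoromethyl on the aryl ring matters in a way the earlier compounds did not reveal, although the step between compound 2 and compound 4 cannot be read.

Still open, on these data alone, is how the loss divides between the urea nitrogen and the halogens. A phenylamino group on the carbonyl carbon would bear on the first, and a methyl, methoxy or nitrile in place of trifluoromethyl would bear on the second.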